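This account rests on a few compounds, and the source may have more. Where it says the series, first, only, none or still open, it means among the compounds named here.

In a functional assay on HCT-116 cells (Homo sapiens) for antiproliferative activity, read by MTT assay, with a stated time of 48 h (a higher number here means a weaker inhibitor, a lower number a stronger inhibitor), compound 1 `CS(=O)(=O)c1ccc(Nc2ncc(F)c(Nc3nc4ccccc4s3)n2)cc1` gives 3270 nM. Compound 2 `Cc1cnc(Nc2ccc(S(C)(=O)=O)cc2)nc1Nc1nc2ccccc2s1` carries methyl in place of fluoro on an aromatic carbon, and in this assay compound 2 gives 760 nM, a change recorded as a 4.3-fold lower number from compound 1 to compound 2 (0.63 log units; beyond the scatter).

Compound 3 `NS(=O)(=O)c1ccc(Nc2nccc(Nc3nc4ccc(F)cc4s3)n2)cc1` rests on a different core, and the difference between the two cores is not broken down here. In this assay compound 3 gives 700 nM, a number alongside that of compound 2 and well separated from that of compound 1.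

Compound 4 `Cc1ccc2nc(Nc3ccnc(Nc4ccc(S(N)(=O)=O)cc4)n3)sc2c1` is not yet measured. Going by the values given here, it differs from compound 3 by methyl in place of fluoro on an aromatic carbon, the same kind of change as the one from compound 1 to compound 2, but not the same: the earlier change sat on a six-membered aromatic ring with 2 nitrogen, ortho to a large group and para to a large group, whereas here it sits on a six-membered aromatic ring of carbon only, part of a fused system of two rings, meta to a fused ring and para to a fused ring. Among the compounds with values here, because the one measured precedent is a 4.3-fold lower number from compound 1 to compound 2 (0.63 log units; beyond the scatter), a smaller step is expected at this other place, a 1.4-fold lower number from compound 3 to compound 4 (0.15 log units; within the scatter). Compound 4 is therefore estimated at 500 nM in this assay, expected between 200 nM and 1300 nM.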

Compound 4, half-maximal inhibitory concentration: 900 nM
For compound 4 the middle estimate is 1.8-fold (0.26 log units) below the measured one, and the stated range covers the measured number.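

In this assay, methyl in place of fluoro on an aromatic carbon of the six-membered ring of carbon only gives a 1.3-fold higher number from compound 3 to compound 4 (0.11 log units; within the scatter), so at this place the swap leaves the number within the scatter. Set beside the earlier step, the same change does not keep its size from one core to the other: the same change on two cores in this assay, a 4.3-fold lower number (0.63 log units; beyond the scatter) from compound 1 to compound 2 and a 1.3-fold higher number (0.11 log units; within the scatter) from compound 3 to compound 4, 5.5-fold (0.74 log units) apart, beyond the scatter of two such steps. The step seen on the core of compound 1 therefore cannot be carried over as a fixed shift, but these two pairs differ both in core and in the place of the change, so they do not show which of the two accounts for the gap.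

As far as these compounds go, it remains open what size of step the same swap would give if made at one place on both cores. Also open, from the compounds shown here alone, is how another group on that aromatic carbon, such as chlorine, a methoxy group or an amine, would compare with methyl and fluoro.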